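The compounds below may be only part of what the source reports. "The series", "measured", "known", "first", "only" and "open" are said of these compounds alone.

Of the compounds shown here, two have so far been measured in a functional assay on HT-29 cells (Homo sapiens) for cytotoxicity, read by MTT assay, with a stated time of 24 h; on this read-out lower numbers stand for stronger inhibition and higher numbers for weaker inhibition. Compound 1 `O=Cc1cc(Br)ccc1OCc1cn(CCCOc2ccc3ccc(=O)oc3c2)nn1` gives 7470 nM in this assay. Compound 2 `NS(=O)(=O)c1ccc(C/N=C/c2ccc(OCc3cn(CCCOc4ccc5ccc(=O)oc5c4)nn3)cc2)cc1` gives 125000 nM, the higher of the two numbers, and the gap to compound 1 lies beyond the usual scatter. Compound 3 `COc1cc(/C=N/Cc2ccc(S(N)(=O)=O)cc2)ccc1OCc1cn(CCCOc2ccc3ccc(=O)oc3c2)nn1` has not yet been measured; it differs from compound 2 by methoxy in place of hydrogen on an aromatic carbon. For the measured compounds named here, no measured pair shows the effect of such a change here, so a change this small is expected to move this assay little, not beyond the scatter, in either direction. Compound 3 is therefore expected to give 110000 nM, with a range from 35000 nM to 350000 nM, a step of a 1.1-fold lower number from compound 2 to compound 3 (0.06 log units; within the scatter).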

Compound 3, half-maximal inhibitory concentration: 31600 nM
Compound 3: middle estimate off by 3.5-fold (0.54 log units), on the high side, and the stated range ends above it.
By their numbers in this assay, from the lowest: compound 1; then compound 3; then compound 2.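

In this assay, methoxy in place of hydrogen on this aromatic carbon, ortho to a large group and meta to a large group, gives a 4.0-fold lower number from compound 2 to compound 3 (0.60 log units; beyond the scatter) and so is not a silent change. For the compounds shown here, this is the first measured pair to show that this position responds to substitution. No measurement at hand accounts for the step.

On these data alone, whether another group here, such as a hydroxyl, a fluorine atom or a longer ethoxy chain, would lower the number further remains open. So does whether methoxy would act alike on other carbons of this ring.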